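Swapping chloro for methoxy on the shared core

The compounds below may be only part of what the source reports. "The series", "measured", "known", "first", "only" and "open" are said of these compounds alone.

Three compounds share one core, differing in the group on the aromatic ring or in the chain on the amine. In a functional assay on 184B5 cells (Homo sapiens) for cytotoxicity, read by sulforhodamine B assay, with a stated time of 48 h, in the presence of a further agent that is not named here (on this read-out lower numbers stand for stronger inhibition of growth and higher numbers for weaker inhibition of growth), compound 1 `CCCCNc1ccnc2cc(Cl)ccc12` gives 16600 nM, and compound 2 `CCCCNc1ccnc2cc(F)ccc12` gives 14900 nM. Compound 3 `CN(C)CCNc1ccnc2cc(Cl)ccc12` reaches only the limit of this assay, > 20000 nM; its result is a boundary rather than a number, and it stands at the limit of > 20000 nM in this assay, at which 1 of the 3 values shown sits. The two measured steps are both small: a 1.1-fold lower number from compound 1 to compound 2 (0.05 log units; within the scatter), and an at least 1.2-fold higher number from compound 1 to compound 3 (0.08 log units; that floor lies within the scatter).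

Compound 4 `COc1ccc2c(NCCN(C)C)ccnc2c1` differs from compound 3 in one place: methoxy in place of chloro on an aromatic carbon. For the measured compounds named here, no measured step swaps chloro for methoxy; the nearest in kind is the exchange of one halogen for another from compound 1 to compound 2, which moved nothing beyond the scatter, and the chain change from compound 1 to compound 3 also stayed near the scatter floor. With compound 3 already at the boundary, the expectation for compound 4 in this assay is no step beyond the scatter, a step that the limit leaves unreadable from compound 3 to compound 4, and a fair chance that only a limit is reported again. Compound 4 is therefore estimated at 25000 nM, with a range from 12000 nM to 50000 nM.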

Compound 4, concentration for 50% growth inhibition: > 20000 nM
Compound 4: a limit, no number; the forecaster's own chance of this, stated with the estimate: 60%; the middle value does not contradict the limit.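

In this assay compound 4 gives > 20000 nM as a limit and not a number. For the compounds shown here, no step from compound 3 to compound 4 can be read, because both compounds stop at a limit: the limit of > 20000 nM in this assay, at which 2 of the 4 values shown sit. The compounds shown leave open whether methoxy in place of chloro on the shared core changes growth inhibition at all.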